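This account rests on a few compounds, and the source may have more. Where it says the series, first, only, none or still open, it means among the compounds named here.

Compound 1, `CS(=O)(=O)c1ccc(Nc2ncc(F)c(Nc3nc4ccc(Cl)cc4s3)n2)cc1`; compound 2, `CS(=O)(=O)c1ccc(Nc2ncc(F)c(Nc3nc4ccc(F)cc4s3)n2)cc1`; compound 3, `COc1ccc2nc(Nc3nc(Nc4ccc(S(C)(=O)=O)cc4)ncc3F)sc2c1`.

In a functional assay on MCF7 cells (Homo sapiens) for antiproliferative activity, read by MTT assay, with a stated time of 48 h (on this read-out lower numbers stand for stronger inhibition and higher numbers for weaker inhibition), compound 1 reaches only the limit of > 50000 nM. Compound 2 likewise reaches only the limit of > 50000 nM. Going by the values given here, compound 3 gives 5850 nM, the sole number in the set, since the other two values sit at the limit of > 50000 nM in this assay, at which 2 of the 3 values shown sit; it is therefore the reference for the next step. Compound 4, `COc1ccc2nc(Nc3ccnc(Nc4ccc(S(C)(=O)=O)cc4)n3)sc2c1`, differs from compound 3 by hydrogen in place of fluoro on an aromatic carbon. Among the compounds with values here, none of the measured steps bears on this position: an at least 8.5-fold lower number from compound 1 to compound 3 (0.93 log units; beyond the scatter), an at least 8.5-fold lower number from compound 2 to compound 3 (0.93 log units; beyond the scatter) and a step that the two limits leave unreadable from compound 1 to compound 2 all concern a different aromatic carbon. The step is thus expected to be a 1.5-fold higher number from compound 3 to compound 4 (0.19 log units; within the scatter), near the scatter. Compound 4 is expected to give 9000 nM, between 3000 nM and 30000 nM.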

Compound 4, half-maximal inhibitory concentration: > 50000 nM
Compound 4: a limit, no number; the forecaster's own chance of this, stated with the estimate: 20%; at least 5.5-fold (0.74 log units) between middle value and limit.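

In this assay, going by these compounds alone, hydrogen in place of fluoro gives an at least 8.5-fold higher number from compound 3 to compound 4 (0.93 log units; beyond the scatter), so this fluoro on the ring with 2 nitrogen counts for compound 3, which no earlier step could show. Compound 4 stands at > 50000 nM, which is a limit and not a number. Compounds 1 and 2 carry the same fluoro without the methoxy and also sit at the limit, so among these compounds a number appears only with methoxy and fluoro together: the limit of > 50000 nM in this assay, at which 3 of the 4 values shown sit.

From the compounds shown here alone, the true size of the step stays open, as does what a chloro, a methyl or an amine on this carbon would give.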